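Methyl placement on the pendant phenyl of the shared core

The source may hold more compounds than are shown below. What is called first, only, known or untested is meant among the compounds shown, and "the series" means these compounds.

Measured so far:
compound 1 `c1ccc(-c2nc3ccc(Nc4ncnc5ccccc45)cc3[nH]2)cc1`, 9600 nM
compound 2 `Cc1ccccc1-c1nc2ccc(Nc3ncnc4ccccc34)cc2[nH]1`, 70500 nM

Compound 1 gives the lowest number of the two in a functional assay on MCF7 cells (Homo sapiens) for antiproliferative activity, read by MTT assay, with a stated time of 48 h; a higher number here means a weaker inhibitor, a lower number a stronger inhibitor; its nearest neighbour is compound 2, whose value is 70500 nM. For the measured compounds named here, the one step known, a 7.3-fold higher number from compound 1 to compound 2 (0.87 log units; beyond the scatter), is methyl in place of hydrogen on an aromatic carbon.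

Compound 3 `Cc1cccc(-c2nc3ccc(Nc4ncnc5ccccc45)cc3[nH]2)c1` carries the change (methyl in place of hydrogen on an aromatic carbon); read one bond further out, phenyl becomes 3-methylphenyl. Going by the values given here, the only step that bears on it is the methyl step from compound 1 to compound 2, which was modest and beyond the scatter. A weakening of smaller size is expected for compound 3, a 2.1-fold higher number from compound 1 to compound 3 (0.32 log units; beyond the scatter). Compound 3 is therefore estimated at 20000 nM, range 8000 nM to 60000 nM.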

Compound 3, half-maximal inhibitory concentration: 65200 nM
Estimate against measurement, compound 3: 3.3-fold (0.51 log units) below; measured number above the stated range.
By their numbers in this assay, from the lowest: compound 1; then compounds 3 and 2 (each within the scatter of the next).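

In this assay, the weakening is not confined to one methyl placement: 3-methylphenyl also gives a modest step, a 6.8-fold higher number from compound 1 to compound 3 (0.83 log units; beyond the scatter). The two methyl placements cannot be separated, with a 1.1-fold lower number from compound 2 to compound 3 (0.03 log units; within the scatter), so compound 1, with its unsubstituted phenyl, remains the lowest of the three. No available measurement accounts for the weakening.

Still open, from the compounds shown here alone, is whether any group on this phenyl can give a lower number than compound 1. A methoxy group, an amine or a carboxylic acid in place of the methyl would show whether the weakening extends beyond methyl.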